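This account rests on a few compounds, and the source may have more. Where it says the series, first, only, none or still open, it means among the compounds named here.

Measured in a functional assay on the whole organism (artery, strain albino) with Rattus norvegicus as the target, with a stated time of 900 min, at a dose of 10 mg/kg by the oral route; a lower number here means less inhibition, a higher number more inhibition at the dose given (going by the name of the read-out):
compound 1, `CC1=C(C(=O)Nc2ccc(Br)cc2)C(c2ccc(Cl)cc2Cl)N=C(SCc2ccccc2Cl)N1`: 16.4%
compound 2, `CC1=C(C(=O)Nc2ccc(Br)cc2)C(c2ccc(Cl)cc2Cl)N=C(SCc2cccc(Cl)c2)N1`: 7.2%
compound 3, `COc1ccc(C2N=C(SCc3ccccc3Cl)NC(C)=C2C(=O)Nc2ccc(Br)cc2)cc1`: 7.2%

Compound 4, `COc1ccc(C2N=C(SCc3cccc(Cl)c3)NC(C)=C2C(=O)Nc2ccc(Br)cc2)cc1`, has not yet been measured in this assay. It is related to compound 3 by 3-chlorophenyl in place of 2-chlorophenyl on a saturated chain carbon bound to a sulfur. The same change occurs once more among these compounds, from compound 1 to compound 2, where it gave a number 9.2 percentage points lower from compound 1 to compound 2 (within the scatter). The core of compound 3 differs from the core of compound 1 by 4-methoxyphenyl in place of 2,4-dichlorophenyl on a saturated ring carbon, and that exchange gave a number 9.2 percentage points lower from compound 1 to compound 3 (within the scatter). The place of the exchange is described in the same words for both pairs, so the change from compound 3 to compound 4 is the same change made on a different core. Among the compounds with values here, compound 2 and compound 3 are level at the digits given, and both steps from compound 1 stay within the usual scatter, so the single earlier instance gives only weak guidance. The step from compound 3 to compound 4 is expected to be a number 3.2 percentage points lower from compound 3 to compound 4 (within the scatter), resting on the earlier instance a number 9.2 percentage points lower from compound 1 to compound 2 (within the scatter). Compound 4 is therefore estimated at 4% in this assay, with a likely range from -8% to 15%.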

Compound 4, a percentage reported as inhibition, in the whole organism at one dose (the size of the read-out at that dose, not a potency): 22.6%
Compound 4: middle estimate off by 18.6 percentage points, on the low side; the whole stated range lies below it.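

In this assay, 3-chlorophenyl in place of 2-chlorophenyl gave a number 15.4 percentage points higher from compound 3 to compound 4 (beyond the scatter), and this change did not carry over unaltered from the core of compound 1 to the core of compound 3: the same change on two cores in this assay, a number 9.2 percentage points lower (within the scatter) from compound 1 to compound 2 and a number 15.4 percentage points higher (beyond the scatter) from compound 3 to compound 4, 24.6 percentage points apart, beyond the scatter of two such steps Read the other way, 4-methoxyphenyl in place of 2,4-dichlorophenyl on a saturated ring carbon gave a number 15.4 percentage points higher from compound 2 to compound 4 (beyond the scatter), so this exchange also depended on its partner group: the same change on two cores in this assay, a number 9.2 percentage points lower (within the scatter) from compound 1 to compound 3 and a number 15.4 percentage points higher (beyond the scatter) from compound 2 to compound 4, 24.6 percentage points apart, beyond the scatter of two such steps Both gaps rest on the same four compounds and count as one observation rather than two, and they neither explain the dependence nor say how any other core would respond.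

The compounds shown leave open whether plain benzyl or 4-chlorobenzyl in place of the 2-chlorobenzyl and 3-chlorobenzyl groups would follow compound 3 or compound 4. They also leave open whether the dependence would persist with 4-fluorophenyl or 4-hydroxyphenyl on the saturated ring carbon.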